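The compounds below may be only part of what the source reports. "The series", "measured", "known", "first", "only" and "open" are said of these compounds alone.

Of the compounds shown here, three with a shared core have been tested in a functional assay on A549 cells (Homo sapiens) for antiproliferative activity, read by CCK-8 assay, with a stated time of 72 h; on this read-out higher numbers stand for weaker inhibition and lower numbers for stronger inhibition. Compound 1 `Nc1ccccc1NC(=O)c1ccc(COc2ccc([N+](=O)[O-])cc2)cc1` gives only a limit of the assay, > 32000 nM. Compound 2 `Nc1ccccc1NC(=O)c1ccc(COc2ccccc2)cc1` gives 6760 nM, and compound 3 `COc1ccc(OCc2ccc(C(=O)Nc3ccccc3N)cc2)cc1` gives 5530 nM. These two numbers sit level, as the step between them shows: a 1.2-fold lower number from compound 2 to compound 3 (0.09 log units; within the scatter). Compound 4 `CC(C)c1ccc(OCc2ccc(C(=O)Nc3ccccc3N)cc2)cc1` has not yet been measured. It differs from compound 3 in one place: isopropyl in place of methoxy on an aromatic carbon, with isopropyl in place of methoxy on an aromatic carbon, para to a large group. For the measured compounds named here, three measured steps concern this same place. Two start from the nitro group of compound 1: an at least 4.7-fold lower number from compound 1 to compound 2 (0.67 log units; beyond the scatter) and an at least 5.7-fold lower number from compound 1 to compound 3 (0.76 log units; beyond the scatter). Going by the values given here, the third, a 1.2-fold lower number from compound 2 to compound 3 (0.09 log units; within the scatter), is the only one between two real numbers, and it stays within the scatter. Among these compounds, only compound 1 stands apart, so no clear shift is expected from swapping methoxy for isopropyl. The expected change is a 1.1-fold lower number from compound 3 to compound 4 (0.04 log units; within the scatter), which means no step beyond the scatter in either direction. For compound 4 the estimated value is 5000 nM, with an expected range of 1800 nM to 16000 nM.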

Compound 4, half-maximal inhibitory concentration: 7460 nM
Compound 4: the middle estimate sits 1.5-fold (0.17 log units) below what was measured; low and high end bracket the measured number.
By their numbers in this assay, from the lowest: compounds 3, 2 and 4 (each within the scatter of the next). At a limit, above all of these: compound 1.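

In this assay, isopropyl joins hydrogen and methoxy as a third group at this place on the ring, and the steps of a 1.3-fold higher number from compound 3 to compound 4 (0.13 log units; within the scatter) and a 1.1-fold higher number from compound 2 to compound 4 (0.04 log units; within the scatter) show no real separation among them. For the compounds shown here, this change swaps methoxy, with its hydrogen-bond acceptor, for a group of more heavy atoms and no acceptor, yet the number does not move beyond the scatter, while nitro remains the one group that stands apart, with an at least 4.2-fold lower number from compound 1 to compound 4 (0.63 log units; beyond the scatter). That step has only one real number behind it, since compound 1 is held at a limit of the assay: the limit of > 32000 nM in this assay, at which 1 of the 4 values shown sits.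

The compounds shown cannot tell why nitro alone stands apart. Going by these compounds, whether an amine or a carboxylic acid at this place would read like nitro or like the other three groups remains open.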